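The compounds below may be only part of what the source reports. "The series", "measured", "known", "first", "only" and "open" are said of these compounds alone.

Measured compounds in a functional assay on DU-145 cells (Homo sapiens) for cytotoxicity, read by MTT assay; a lower number here means a stronger inhibitor, a higher number a weaker inhibitor:

compound 1, `CC(O)(CS(=O)(=O)c1ccc(Br)cc1)c1nc(-c2ccccc2)no1`: > 100000 nM (a limit of the assay, not a number)
compound 2, `CC(O)(CS(=O)(=O)c1ccccc1)c1nc(-c2ccc(Cl)cc2)no1`: > 100000 nM (a limit of the assay, not a number)

Compound 2 stands at the limit of this assay, where its reading of > 100000 nM is a limit and not a measured number. Compound 1 sits at the same limit, with > 100000 nM. Both values shown thus fall on one line: the limit of > 100000 nM in this assay, at which 2 of the 2 values shown sit. Among the measured compounds shown here, no step between two measured compounds can be drawn from such readings, so no measured step size exists.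

Compound 3, `CC(O)(CS(=O)(=O)c1ccc(Br)cc1)c1nc(-c2ccc(Cl)cc2)no1`, differs from compound 2 by bromo in place of hydrogen on an aromatic carbon. Compound 3 carries both the bromo group found in compound 1 and the chloro group found in compound 2, each of which, on its own, left its compound at the limit.

With no numbered value on either side, the expected step from compound 2 to compound 3 is a number no higher from compound 2 to compound 3 (the limit leaves the size open), none beyond the usual scatter. Compound 3 is accordingly estimated at 100000 nM, within a range of 30000 nM to 300000 nM, and most likely reported only as a limit again.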

Compound 3, half-maximal inhibitory concentration: > 100000 nM
Compound 3 gave a limit, no number; the forecaster's own chance of this, stated with the estimate: 85%; the middle value lies on the limit itself.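

In this assay compound 3 gives > 100000 nM, a limit and not a number. Among the compounds shown here, no step from compound 1 or compound 2 to compound 3 can be read, because all the readings lie on one line: the limit of > 100000 nM in this assay, at which 3 of the 3 values shown sit. The compounds shown leave open how far compound 1, compound 2 and compound 3 differ from one another in this assay.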